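This account rests on a few compounds, and the source may have more. Where it says the series, first, only, none or still open, it means among the compounds named here.

Compound 1 `CCCCCCCCCCCCCC/N=c1\nc(N)c2ncn(Cc3ccccc3)c2c(N)n1` and compound 2 `CCCCCCCC/N=c1\nc(N)c2ncn(Cc3ccccc3)c2c(N)n1` share a core that carries a benzyl group, while compound 3 `CC/N=c1\nc(N)c2nc[nH]c2c(N)n1` has a core in which that position bears only hydrogen; how the two cores differ is not broken down here. In a functional assay on A549 cells (Homo sapiens) for antiproliferative activity, read by WST assay, with a stated time of 72 h (on this read-out higher numbers stand for weaker inhibition and lower numbers for stronger inhibition), compound 1 gives 4250 nM, and compound 2 gives 3830 nM, a difference of a 1.1-fold higher number from compound 2 to compound 1 (0.05 log units; within the scatter). That step is hexyl in place of hydrogen on a saturated chain carbon, eight bonds along the chain from a double-bonded nitrogen. Compound 3 in this assay gives 38000 nM, the highest number of the three.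

Compound 4 `CCCCCCCC/N=c1\nc(N)c2nc[nH]c2c(N)n1` has not yet been measured. It differs from compound 3 by hexyl in place of hydrogen on a saturated chain carbon, two bonds along the chain from a double-bonded nitrogen. This is the same kind of change as that from compound 2 to compound 1, but not the same: there the hexyl entered eight bonds along the chain from a double-bonded nitrogen, here it enters two bonds along the chain from a double-bonded nitrogen. Because the earlier step of a 1.1-fold higher number from compound 2 to compound 1 (0.05 log units; within the scatter) lay within the scatter, the expected step for compound 4 is small, a 1.9-fold lower number from compound 3 to compound 4 (0.28 log units; within the scatter), with wide uncertainty since no other chain change on the core of compound 3 is known. In this assay compound 4 is expected to give 20000 nM, estimated between 5000 nM and 60000 nM.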

Compound 4, half-maximal inhibitory concentration: "not active" (no number reported)
Nothing numeric was reported for compound 4; there is nothing to compare the estimate with.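

In this assay, within the data shown here, compound 4 is reported only as "not active", without a number, so no step from compound 3 to compound 4 can be read. The compounds shown leave open how a longer chain on the core of compound 3 relates to activity, since only compound 3 carries a number on that core. No measurement given here offers an explanation for this result.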